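The compounds below may be only part of what the source reports. "The series", "measured", "known", "first", "only" and "open" are said of these compounds alone.

The series gathers three measured compounds and one that still awaits measurement. Compound 2 `Oc1ccccc1-c1cc(-c2ccccc2O)nc(-c2ccccc2O)c1`, compound 3 `Oc1cccc(-c2cc(-c3ccccc3O)cc(-c3ccccc3O)n2)c1` and compound 1 `Oc1ccc(-c2cc(-c3ccccc3O)cc(-c3cccc(O)c3)n2)cc1` are built from the same atoms joined differently. In an ADME assay on HEK293 cells (Homo sapiens) for cytotoxicity, read by CCK-8 assay, with a stated time of 4 days (on this read-out higher numbers stand for weaker inhibition and lower numbers for stronger inhibition), compound 2 gives 140 nM, the lowest of the three numbers. The core of compound 3 differs from that of compound 2 by 2-hydroxyphenyl in place of 3-hydroxyphenyl on an aromatic carbon. In this assay compound 3 gives 730 nM. That amounts to a 5.2-fold higher number from compound 2 to compound 3 (0.72 log units; beyond the scatter). Compound 1 differs from compound 3 by 4-hydroxyphenyl in place of 2-hydroxyphenyl on an aromatic carbon. In this assay compound 1 gives 5650 nM. That corresponds to a 7.7-fold higher number from compound 3 to compound 1 (0.89 log units; beyond the scatter).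

The unmeasured compound 4 `Oc1ccc(-c2cc(-c3ccccc3O)nc(-c3ccccc3O)c2)cc1` differs from compound 2 by 4-hydroxyphenyl in place of 2-hydroxyphenyl on an aromatic carbon. This is the same kind of change as that from compound 3 to compound 1, though not the same: there the exchanged group sat next to the ring nitrogen, meta to a 2-hydroxyphenyl group and meta to a 3-hydroxyphenyl group, whereas in compound 4 it sits opposite the ring nitrogen, meta to two 2-hydroxyphenyl groups. Because the earlier exchange produced a 7.7-fold higher number from compound 3 to compound 1 (0.89 log units; beyond the scatter), a step of comparable size, a 6.4-fold higher number from compound 2 to compound 4 (0.81 log units; beyond the scatter), is expected in this assay. This expectation rests on a single prior pair, so it carries a wide margin. Compound 4 is therefore estimated at 900 nM in this assay, with a likely range from 350 nM to 2500 nM.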

Compound 4, half-maximal inhibitory concentration: > 50000 nM
Compound 4: a limit, no number; the forecaster's own chance of this, stated with the estimate: 5%; middle value at least 55-fold (1.74 log units) from the limit.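

Compound 4 gives > 50000 nM in this assay, which is a limit of the assay and not a number. With 4-hydroxyphenyl in place of 2-hydroxyphenyl opposite the ring nitrogen, the result is an at least 350-fold higher number from compound 2 to compound 4 (2.55 log units; beyond the scatter), so the exchange raises the number on both cores but does not carry over from one core to the other at one size: the same change on two cores in this assay, a 7.7-fold higher number (0.89 log units; beyond the scatter) from compound 3 to compound 1 and an at least 350-fold higher number (2.55 log units; beyond the scatter) from compound 2 to compound 4, at least 46-fold (1.66 log units) apart, beyond the scatter of two such steps Only two pairs bear on this and one of them ends at a limit, so the true size of the second step stays unknown, and the pairs give no reason for the gap between the steps; the limit is also reached by just one of the compounds: the limit of > 50000 nM in this assay, at which 1 of the 4 values shown sits.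

All the compounds shown carry hydroxyphenyl groups and differ only in where the hydroxyl sits on them, which leaves open whether the steep rise in the number would persist with a methoxy group or an amine in the place of that hydroxyl. They also leave open how 3-hydroxyphenyl would read in the place opposite the ring nitrogen, where only 2-hydroxyphenyl and 4-hydroxyphenyl appear here.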